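Urea-to-benzamide change with loss of ring substituents

The source may hold more compounds than are shown below. What is called first, only, known or untested is meant among the compounds shown, and "the series" means these compounds.

Measured so far in a functional assay on MDA-MB-435 cells (Homo sapiens) for inhibition, read by sulforhodamine B assay, with a stated time of 48 h; a higher number here means a weaker inhibitor, a lower number a stronger inhibitor:
- compound 1 `COc1cc(-c2nn(-c3cccc(NC(=O)Nc4cccc(C(F)(F)F)c4)c3)cc2-c2ccncc2)ccc1Cl`: 870 nM
- compound 2 `COc1cc(-c2nn(-c3cccc(NC(=O)c4ccc(Cl)c(C(F)(F)F)c4)c3)cc2-c2ccncc2)ccc1Cl`: 660 nM
- compound 3 `COc1cc(-c2nn(-c3cccc(NC(=O)Nc4ccc(Cl)c(C(F)(F)F)c4)c3)cc2-c2ccncc2)ccc1Cl`: 680 nM

All three numbers sit close together. Compound 3 holds the second highest number of the three; its nearest neighbour is compound 2, and the gap a 1.0-fold higher number from compound 2 to compound 3 (0.01 log units; within the scatter) carries no information on direction. Against compound 1 the gap a 1.3-fold lower number from compound 1 to compound 3 (0.11 log units; within the scatter) is likewise inside the scatter.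

Compound 4 `COc1cc(-c2nn(-c3cccc(NC(=O)c4ccccc4)c3)cc2-c2ccncc2)ccc1Cl` is not yet measured. Its difference from compound 3 is phenyl in place of (4-chloro-3-(trifluoromethyl)phenyl)amino on a carbonyl carbon. Among the measured compounds shown here, two measured steps touch parts of this change. The exchange of an amide-type carbonyl neighbour for the corresponding amino-linked one, with the same substituted ring, is seen in a 1.0-fold higher number from compound 2 to compound 3 (0.01 log units; within the scatter) and was flat. Removal of a single chloro from the ring is seen, in reverse, in a 1.3-fold lower number from compound 1 to compound 3 (0.11 log units; within the scatter) and was also flat. For the measured compounds named here, no measured pair tests the removal of the trifluoromethyl group, so that part of the change is uncovered by the data.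

On this basis the step to compound 4 in this assay is expected to be small, if anything toward a higher number, as a 2.2-fold higher number from compound 3 to compound 4 (0.34 log units; beyond the scatter). Compound 4 is estimated at 1500 nM, with a range from 500 nM to 5000 nM.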

Compound 4, half-maximal inhibitory concentration: 190 nM
Beside the measured number, compound 4's estimate is 7.9-fold (0.90 log units) above it; measured number outside the range, below it.
By their numbers in this assay, from the lowest: compound 4; then compounds 2, 3 and 1 (each within the scatter of the next).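

In this assay, among the compounds shown here, the unsubstituted phenyl on the carbonyl carbon is the first change to move the number beyond the scatter, with a 3.6-fold lower number from compound 3 to compound 4 (0.55 log units; beyond the scatter) set against the flat steps among the three earlier compounds, and compound 4 is the strongest of the four, as a 4.6-fold lower number from compound 1 to compound 4 (0.66 log units; beyond the scatter) also shows. The amide link is the same on both sides of a 3.5-fold lower number from compound 2 to compound 4 (0.54 log units; beyond the scatter) so the drop appears with only the chloro and trifluoromethyl groups gone from the ring, and the urea link is not required for it. Nothing at hand gives a reason for this drop.

Compounds 2 and 4 differ by both ring substituents at once, so the share of the chloro and the share of the trifluoromethyl group stay unseparated, and the phenylamino counterpart of compound 4 would be needed to test whether the unsubstituted ring gives the same result on the urea link. Going by these compounds, how far the unsubstituted ring can be changed also stays open, for example with a single fluorine, a methoxy group, an amine or a carboxylic acid on it.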